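Truncating the amine substituent to benzyl in the sulfonamide series

The source may hold more compounds than are shown below. What is called first, only, known or untested is meant among the compounds shown, and "the series" means these compounds.

The series shares a bis(trifluoromethyl)benzenesulfonamide core linked through a short diamine chain to a variable group on the amine nitrogen. Compound 1 `CC(C)(C)c1ccc(CNCCCNS(=O)(=O)c2cc(C(F)(F)F)cc(C(F)(F)F)c2)cc1` gives 2100 nM in a functional assay on MCF7 cells (Homo sapiens) for inhibition, read by MTT assay, with a stated time of 72 h; a higher number here means a weaker inhibitor of growth, a lower number a stronger inhibitor of growth. Compound 2 `O=S(=O)(NCCCCNCc1ccc(Br)cc1)c1cc(C(F)(F)F)cc(C(F)(F)F)c1`, which carries a longer chain, gives 1500 nM in this assay. Compound 3 `O=S(=O)(NCCCNCC1COc2ccccc2O1)c1cc(C(F)(F)F)cc(C(F)(F)F)c1` gives 2500 nM in this assay, the highest of the three numbers, though its gaps to compound 1 and to compound 2 are both within the scatter; no order among the three can be read.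

The new compound 4 `O=S(=O)(NCCCNCc1ccccc1)c1cc(C(F)(F)F)cc(C(F)(F)F)c1` differs from compound 3 by phenyl in place of 2,3-dihydro-1,4-benzodioxin-2-yl on a saturated chain carbon bound to an amine nitrogen. Within the data shown here, the only measured step at this position, a 1.2-fold higher number from compound 1 to compound 3 (0.08 log units; within the scatter), was within the scatter, and compound 2 offers no step to compound 3. On that basis no step beyond the scatter is expected for compound 4, with a 1.1-fold lower number from compound 3 to compound 4 (0.06 log units; within the scatter) as the estimated change. Compound 4 is therefore expected to give 2200 nM in this assay, with a range from 1000 nM to 5000 nM.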

Compound 4, concentration for 50% growth inhibition: 3000 nM
Estimate against measurement, compound 4: 1.4-fold (0.13 log units) below; the range from low to high includes it.
By their numbers in this assay, from the lowest: compounds 2, 1, 3 and 4 (each within the scatter of the next).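

Replacing 2,3-dihydro-1,4-benzodioxin-2-yl with phenyl on this saturated chain carbon removes a six-membered non-aromatic ring and both hydrogen-bond acceptors of the leaving group, yet this assay shows only a 1.2-fold higher number from compound 3 to compound 4 (0.08 log units; within the scatter). The plain benzyl group also stays within the scatter of the substituted benzyl compounds, with a 1.4-fold higher number from compound 1 to compound 4 (0.15 log units; within the scatter) on loss of tert-butyl and a 2.0-fold higher number from compound 2 to compound 4 (0.30 log units; within the scatter) for the change that also shortens the chain, so neither tert-butyl nor the bromine with the longer chain is shown to matter here. No supporting measurement bears on these results.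

As far as these compounds go, whether a carboxylic acid or a pyridine ring in place of phenyl would move the number beyond the scatter remains open. From the compounds shown here alone, the effect of a longer chain alone on the plain benzyl compound also remains open.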